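Sulfur substituents: compound 3 to compound 4

A few compounds are considered here, and "the series" means these few. Any claim that something is new, unique, unknown or untested is made for them only; others in the source may bear on it.

Measured so far in a functional assay on PC-9 cells (Homo sapiens) for antiproliferative activity, read by MTT assay; a higher number here means a weaker inhibitor, a lower number a stronger inhibitor
- compound 1 `C#CCSc1nc(Sc2nc(C)c(C)s2)c(C#N)c(-c2cc(OC)c(OC)c(OC)c2)n1` gives > 20000 nM (a limit)
- compound 2 `C#CCSc1nc(Sc2ccccn2)c(C#N)c(-c2cc(OC)c(OC)c(OC)c2)n1` gives > 20000 nM (a limit)
- compound 3 `C#CCSc1nc(Sc2nncs2)c(C#N)c(-c2cc(OC)c(OC)c(OC)c2)n1` gives 7960 nM

Compound 3 alone gives a number. Compound 1 and compound 2 share (the limit of > 20000 nM in this assay, at which 2 of the 3 values shown sit). Compound 4 `C#CCSc1nc(Sc2nc[nH]n2)c(C#N)c(-c2cc(OC)c(OC)c(OC)c2)n1` carries 1H-1,2,4-triazol-3-yl in place of 1,3,4-thiadiazol-2-yl on a sulfur. Both groups are five-membered aromatic rings.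

The measured steps that bear on this change all alter the group on that same sulfur. Both an at least 2.5-fold lower number from compound 1 to compound 3 (0.40 log units; beyond the scatter) and an at least 2.5-fold lower number from compound 2 to compound 3 (0.40 log units; beyond the scatter) lie beyond the scatter, and each gives only a minimum size. The third, a step that the two limits leave unreadable from compound 1 to compound 2, gives no readable size. Together they show that the group on this sulfur can move the result in this assay, but no measured step starts from compound 3 and none involves 1H-1,2,4-triazol-3-yl. On these data alone, the direction therefore stays open, and the best expectation is no step beyond the scatter, with a wide margin on both sides. The expected change is a 1.1-fold higher number from compound 3 to compound 4 (0.05 log units; within the scatter). A reported limit would remain a real possibility. For compound 4 the estimate is 9000 nM, with an expected range from 2500 nM to 25000 nM.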

Compound 4, half-maximal inhibitory concentration: > 20000 nM
Compound 4: a limit, no number; the forecaster's own chance of this, stated with the estimate: 30%; at least 2.2-fold (0.34 log units) between middle value and limit.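

Among the compounds shown here, the change on this sulfur from 1,3,4-thiadiazol-2-yl to 1H-1,2,4-triazol-3-yl gives an at least 2.5-fold higher number from compound 3 to compound 4 (0.40 log units; beyond the scatter), the first measured step that starts from compound 3, and because compound 4 sits at a limit, only a minimum size is known. Both groups are five-membered aromatic rings with 3 hetero atoms, so that shared ring type alone does not keep a number in this assay; the enters and leaves differ in ring atoms and in the hydrogen-bond count. The steps to compound 4 from compound 1 and from compound 2 cannot be read, and 1,3,4-thiadiazol-2-yl remains the only group on this sulfur that gives a number: the limit of > 20000 nM in this assay, at which 3 of the 4 values shown sit.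

The compounds shown do not separate the loss of the ring sulfur from the gain of the ring hydrogen-bond donor, and how far compound 4 lies past its limit stays unknown. Also open, on these data alone, is whether a simple amine or a short chain ending in a carboxylic acid on this sulfur would give a number that differs from compound 3, at 7960 nM.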